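Fluoro for chloro on the arylsulfonyl group

This account rests on a few compounds, and the source may have more. Where it says the series, first, only, none or still open, it means among the compounds named here.

In a functional assay on RS4-11 cells (Homo sapiens) for inhibition, read by CCK-8 assay, with a stated time of 48 h, tested at 20 uM (a higher number here means more inhibition of growth at the concentration tested, a lower number less inhibition of growth), compound 1 `N#C/C(=C\c1ccccc1OS(=O)(=O)c1ccccc1[N+](=O)[O-])C(=O)Nc1nnc(Cc2ccc(Cl)cc2)s1` gives 65% and compound 2 `N#C/C(=C\c1ccccc1OS(=O)(=O)c1ccc(Cl)cc1)C(=O)Nc1nnc(Cc2ccc(Cl)cc2)s1` gives 64%, two values within the scatter of each other. Compound 3 `N#C/C(=C\c1ccccc1OS(=O)(=O)c1ccc(F)cc1)C(=O)Nc1nnc(Cc2ccc(Cl)cc2)s1` carries fluoro in place of chloro on an aromatic carbon, para to a large group: fluoro in place of chloro on an aromatic carbon. Among the measured compounds shown here, one measured step bears on this change: a number 1 percentage points lower from compound 1 to compound 2 (within the scatter), with 4-chlorophenyl in place of 2-nitrophenyl on a sulfonyl sulfur. The expected step in this assay is a number 2 percentage points lower from compound 2 to compound 3 (within the scatter), with no move beyond the scatter. Compound 3 is estimated at 62%, with an expected range of 50% to 74%.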

Compound 3, percent growth inhibition at one concentration: 64%
Estimate against measurement, compound 3: 2 percentage points below; the range from low to high includes it.
By their numbers in this assay, from the lowest: compounds 2, 3 and 1 (each within the scatter of the next).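

In this assay, fluoro in place of chloro gives no change at the digits printed from compound 2 to compound 3 (within the scatter), so at this position the two halogens cannot be told apart at the single concentration tested. Compared with the 2-nitrophenyl group, 4-fluorophenyl gives a number 1 percentage points lower from compound 1 to compound 3 (within the scatter), which places all three arylsulfonyl groups shown within the scatter of one another. Nothing available explains this result. Still open, as far as these compounds go, is whether an amine or a carboxylic acid in place of the fluoro would keep the number within the scatter. A single-concentration read-out also leaves open whether these compounds differ in their full concentration response.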